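The source may hold more compounds than are shown below. What is called first, only, known or untested is meant among the compounds shown, and "the series" means these compounds.

Compound 1 `COc1ccc(-c2ssc(=O)c2-c2cc(OC)c(OC)c(OC)c2)cc1O` and compound 2 `COc1ccc(-c2ssc(=O)c2-c2cc(OC)c(OC)c(OC)c2)cc1N` share one core, and compound 2 carries amino in place of hydroxy on an aromatic carbon in place of what compound 1 bears. In a functional assay on KB cells (Homo sapiens) for antiproliferative activity, read by MTT assay, with a stated time of 72 h (on this read-out lower numbers stand for stronger inhibition and higher numbers for weaker inhibition), compound 1 gives 460 nM, whereas compound 2 gives 60 nM, a step of a 7.7-fold lower number from compound 1 to compound 2 (0.88 log units; beyond the scatter). Compound 3 `CO/N=c1/ssc(-c2ccc(OC)c(O)c2)c1-c1cc(OC)c(OC)c(OC)c1` is built on a different core; the difference between the two cores is not broken down here. In this assay compound 3 gives 14500 nM, the highest number among the three measured compounds. Compound 4 `CO/N=c1/ssc(-c2ccc(OC)c(N)c2)c1-c1cc(OC)c(OC)c(OC)c1` has not yet been measured and differs from compound 3 by amino in place of hydroxy on an aromatic carbon, the same change seen between compound 1 and compound 2. Compound 4 is expected to improve on compound 3 by about a 5.8-fold lower number from compound 3 to compound 4 (0.76 log units; beyond the scatter), because the same change gave a 7.7-fold lower number from compound 1 to compound 2 (0.88 log units; beyond the scatter), though the core differs. Compound 4 is therefore estimated at 2500 nM, expected between 600 nM and 10000 nM.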

Compound 4, half-maximal inhibitory concentration: 4330 nM
Beside the measured number, compound 4's estimate is 1.7-fold (0.24 log units) below it, within the range that was stated.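

In this assay, amino in place of hydroxy on the core of compound 3 gives a 3.3-fold lower number from compound 3 to compound 4 (0.52 log units; beyond the scatter), the same direction as on the core of compound 1. The size of the step does not differ measurably on the two cores, so in this pair of cores the change carries over: the same change on two cores in this assay, a 7.7-fold lower number (0.88 log units; beyond the scatter) from compound 1 to compound 2 and a 3.3-fold lower number (0.52 log units; beyond the scatter) from compound 3 to compound 4, 2.3-fold (0.36 log units) apart, within the scatter of two such steps. This rests on a single pair on each core, so it does not show that the step would hold on a third core, nor why the number falls on either one.

The compounds shown leave open how other groups on that aromatic carbon, such as a methylamino group, an acetamide or a fluorine atom, would compare with amino and hydroxy. They also leave open whether any such group would behave alike on both cores.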